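The compounds below may be only part of what the source reports. "The series", "measured", "known", "first", "only" and "open" are said of these compounds alone.

Values in an ADME assay on L132 cells (Homo sapiens) for cytotoxicity, read by MTT assay, with a stated time of 72 h; on this read-out higher numbers stand for weaker inhibition and lower numbers for stronger inhibition:
- compound 1 `COc1ccc(C2=C(c3cc(OC)c(OC)c(OC)c3)C(=O)C(OC(C)=O)C2)cc1OC(C)C`: > 100 ug/mL (a limit)
- compound 2 `COc1ccc(C2=C(c3cc(OC)c(OC)c(OC)c3)C(=O)C(OC(C)=O)C2)cc1`: > 100 ug/mL (a limit)
- compound 3 `COc1ccc(C2=C(c3cc(OC)c(OC)c(OC)c3)C(=O)C(O)C2)cc1`: < 1 ug/mL (a limit)

Compound 2 gives > 100 ug/mL in this assay, which is a limit and not a number. It stands at the limit of > 100 ug/mL in this assay, at which 2 of the 3 values shown sit, so any later comparison with compound 2 starts from a limit.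

Compound 4 `COc1ccc(C2=C(c3cc(OC)c(OC)c(OC)c3)C(=O)C(OC(C)=O)C2)cc1F` differs from compound 2 by one change: fluoro in place of hydrogen on an aromatic carbon. The new fluoro group sits ortho to a methoxy group.

Among the compounds with values here, two measured steps bear on this only in part. The step on an aromatic carbon, with hydrogen in place of isopropoxy, is a step that the two limits leave unreadable from compound 1 to compound 2, so it gives no size to carry over. Within the data shown here, the only large step is an at least 100-fold lower number from compound 2 to compound 3 (2.00 log units; beyond the scatter). That step removes the acetyl from an oxygen on a saturated carbon, and compound 4 keeps this acetyl, as compound 2 does. It therefore sets no size for a change on the aromatic ring.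

The expected result in this assay is a number no higher from compound 2 to compound 4 (the limit leaves the size open), with no shift beyond the scatter anticipated. Compound 4 is estimated at 100 ug/mL, with an expected range of 40 ug/mL to 250 ug/mL.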

Compound 4, half-maximal inhibitory concentration: < 1 ug/mL
Compound 4: no number, only a limit; the forecaster's own chance of this, stated with the estimate: 75%; middle value at least 100-fold (2.00 log units) from the limit.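

In this assay, within the data shown here, a single fluoro on the aromatic carbon ortho to a methoxy group gives an at least 100-fold lower number from compound 2 to compound 4 (2.00 log units; beyond the scatter), with the acetyl on the saturated carbon still in place, so removing that acetyl is not the only one-place change that moves the read-out from one limit to the other. At this same aromatic carbon, fluoro in place of isopropoxy gives an at least 100-fold lower number from compound 1 to compound 4 (2.00 log units; beyond the scatter), which shows that the carbon matters and that the identity of its substituent decides the outcome: hydrogen and isopropoxy both leave the read-out at the upper limit, and fluoro does not. The result for compound 4 is itself a limit, and it sits at the same limit as the free alcohol compound 3: the limit of < 1 ug/mL in this assay, at which 2 of the 4 values shown sit.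

As far as these compounds go, with both compounds reported only as limits, the true size of each step and any difference between compound 3 and compound 4 remain unknown. Also open, from the compounds shown here alone, are whether a chloro, a nitrile or a methyl group on this carbon would behave like fluoro, and what fluoro does when combined with the free hydroxyl on the saturated carbon.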